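A sultam ring in place of the nitrile

A few compounds are considered here, and "the series" means these few. Any claim that something is new, unique, unknown or untested is made for them only; others in the source may bear on it.

The shared core of this series is a diaryl ether bearing a (methylamino)methyl group, as in compound 1 `CNCc1ccccc1Oc1ccc(Cl)cc1F`, for which an assay on HEK293 cells for inhibition of sodium-dependent dopamine transporter (Homo sapiens) (a lower number here means a stronger inhibitor, a higher number a weaker inhibitor), reports "not determined" (no result reported). Compound 2 `CNCc1cc(C#N)ccc1Oc1ccc(Cl)cc1OC` reaches only a limit in this assay, > 40000 nM. That entry is the limit of > 40000 nM in this assay, at which 1 of the 3 values shown sits, not a number. Compound 3 `CNCc1cc(C#N)ccc1Oc1ccc(Cl)cc1Cl` gives 3010 nM in this assay, the only numerical result among the three compounds, so it stands alone as the point of reference. Among the compounds with values here, the step of an at least 13-fold lower number from compound 2 to compound 3 (1.12 log units; beyond the scatter) is the single measured change, and it lies on the other aromatic ring. Compound 4 `CNCc1cc(N2CCCS2(=O)=O)ccc1Oc1ccc(Cl)cc1Cl` differs from compound 3 elsewhere: a group of 7 heavy atoms (3 carbon, 1 nitrogen, 2 oxygen, 1 sulfur; one five-membered non-aromatic ring with 2 hetero atoms) in place of a group of 2 heavy atoms (1 carbon, 1 nitrogen; no ring), on an aromatic carbon. Within the data shown here, no measured step touches that place, so the expectation rests on no measured precedent and carries wide uncertainty. The estimate for compound 4 in this assay is 4500 nM, with a range of 900 nM to 25000 nM. The expected step of a 1.5-fold higher number from compound 3 to compound 4 (0.17 log units; within the scatter) is thus modest and may fall within the scatter.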

Compound 4, half-maximal inhibitory concentration: 138 nM
Compound 4: middle estimate off by 33-fold (1.51 log units), on the high side, and the stated range ends above it.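

The position meta to the (methylamino)methyl group, untouched by any earlier measured step, turns out to respond strongly in this assay: replacing cyano with the five-membered non-aromatic ring with 2 hetero atoms gives a 22-fold lower number from compound 3 to compound 4 (1.34 log units; beyond the scatter). Within the data shown here, the only earlier measured step lay on the other aromatic ring, so this is the first sign that the ring carrying the (methylamino)methyl group can also shift the number by a large margin. Nothing shown here accounts for the size of this step.

The compounds shown leave open whether the ring itself is needed at this position, or whether an open-chain sulfonamide, a simple amide or a primary amine would serve as well. They also leave open whether the step would hold with methoxy in place of chloro on the other aromatic ring.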